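The source may report more compounds than this note shows. Statements on the series, on what has been measured and on what is new or still open speak of the compounds shown alone.

Measured so far:
Compound 1, `C#Cc1cccc(Nc2ncnc3ccc(NC(=S)Nc4ccc(S(N)(=O)=O)cc4)cc23)c1`, gives 15300 nM in a functional assay on A-431 cells (Homo sapiens) for antiproliferative activity, read by MTT assay, with a stated time of 72 h; a higher number here means a weaker inhibitor, a lower number a stronger inhibitor.
Compound 2, `NS(=O)(=O)c1ccc(NC(=S)Nc2ccc3ncnc(Nc4ccc(C(F)(F)F)cc4)c3c2)cc1`, gives 18000 nM in this assay.

For the measured compounds named here, compound 2 shows the highest of the two numbers, yet its only neighbour, compound 1, lies within the scatter of it: the step of a 1.2-fold higher number from compound 1 to compound 2 (0.07 log units; within the scatter) exchanged one aryl group for another on a nitrogen on an aromatic ring. Compound 3, `Cc1ccc(Nc2ncnc3ccc(NC(=S)Nc4ccc(S(N)(=O)=O)cc4)cc23)cc1`, carries methyl in place of trifluoromethyl on an aromatic carbon, a change on that same aryl group. Going by the values given here, the single step that bears on it, a 1.2-fold higher number from compound 1 to compound 2 (0.07 log units; within the scatter), stayed within the scatter, so no shift beyond the scatter is expected here either. Compound 3 is estimated at 16000 nM, with a range from 6000 nM to 42000 nM, which means an expected step of a 1.1-fold lower number from compound 2 to compound 3 (0.05 log units; within the scatter).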

Compound 3, half-maximal inhibitory concentration: 40000 nM
Estimate against measurement, compound 3: 2.5-fold (0.40 log units) below; the range from low to high includes it.
By their numbers in this assay, from the lowest: compounds 1 and 2 (each within the scatter of the next); then compound 3.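

Methyl in place of trifluoromethyl on this aromatic carbon gave the first shift beyond the scatter in this assay (a 2.2-fold higher number from compound 2 to compound 3 (0.35 log units; beyond the scatter)), although the earlier exchange of aryl groups at the same nitrogen had stayed within it. The 4-methylphenyl group also stands apart from 3-ethynylphenyl (a 2.6-fold higher number from compound 1 to compound 3 (0.42 log units; beyond the scatter)), so compound 3 has the highest number of the three, though both steps are modest. Nothing available explains this shift. From the compounds shown here alone, it remains open whether a chlorine, a methoxy group or an amine on this aromatic carbon would lower the number or raise it further.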